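Amide aryl variation in a dimethoxy tetralin series

The source may hold more compounds than are shown below. What is called first, only, known or untested is meant among the compounds shown, and "the series" means these compounds.

Three amides of the shared core have been run in a functional assay on the whole organism (strain Wistar) for inhibition, with Rattus norvegicus as the target, read by paw edema, with a stated time of 3 h, at a dose of 100 mg/kg; a lower number here means less inhibition, a higher number more inhibition at the dose given (going by the name of the read-out). Compound 1 `COc1cc2c(cc1OC)C(CC(=O)Nc1ccc(Cl)cc1)CC2` gives 60.9%. Compound 2 `COc1cc2c(cc1OC)C(CC(=O)Nc1ccccc1C)CC2` gives 26.1%, and compound 3 `COc1cc2c(cc1OC)C(CC(=O)Nc1ccc(C)cc1)CC2` gives 34.8%. Among these three numbers compound 3 stands second highest; its nearest neighbour is compound 2, and the gap between them, a number 8.7 percentage points higher from compound 2 to compound 3 (within the scatter), lies within the scatter. Its furthest neighbour is compound 1, with a number 26.1 percentage points lower from compound 1 to compound 3 (beyond the scatter). The largest step seen so far is a number 34.8 percentage points lower from compound 1 to compound 2 (beyond the scatter).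

The next compound, compound 4 `COc1cc2c(cc1OC)C(CC(=O)Nc1ccccn1)CC2`, differs from compound 3 by pyridin-2-yl in place of 4-methylphenyl on an amide-type nitrogen. Within the data shown here, no measured step swaps a carbon-only ring for a ring carrying a hetero atom, so the change has no direct precedent in this set. Among the measured compounds shown here, the steps that bear on it are the other exchanges on the amide nitrogen: a number 8.7 percentage points higher from compound 2 to compound 3 (within the scatter) was within the scatter, while a number 34.8 percentage points lower from compound 1 to compound 2 (beyond the scatter) and a number 26.1 percentage points lower from compound 1 to compound 3 (beyond the scatter) were larger. A shift in this assay of comparable size is therefore expected, with no firm direction. Compound 4 is expected to give 35%, in the range 12% to 58%. The step this estimate means is a number 0.2 percentage points higher from compound 3 to compound 4 (within the scatter).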

Compound 4, a percentage reported as inhibition, in the whole organism at one dose (the size of the read-out at that dose, not a potency): 30.4%
Estimate against measurement, compound 4: 4.6 percentage points above; low and high end bracket the measured number.
By their numbers in this assay, from the lowest: compounds 2, 4 and 3 (each within the scatter of the next); then compound 1.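

Pyridin-2-yl on the amide-type nitrogen brings the first ring with a hetero atom into the set, and in this assay it cannot be told apart from either methylphenyl amide: a number 4.4 percentage points lower from compound 3 to compound 4 (within the scatter) and a number 4.3 percentage points higher from compound 2 to compound 4 (within the scatter) are the two steps. The 4-chlorophenyl amide alone stands apart, with a number 30.5 percentage points lower from compound 1 to compound 4 (beyond the scatter) joining its two earlier gaps beyond the scatter, so compounds 2, 3 and 4 sit at one level in this set. Nothing measured here accounts for this pattern.

The compounds shown leave open whether the standing of compound 1 is particular to chloro or extends to other groups on the ring, such as 4-bromophenyl or 4-methoxyphenyl. They also leave open how pyridin-3-yl or pyridin-4-yl would compare with pyridin-2-yl.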